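Benzoylguanidine series: aryl thioether to isopropoxy

The source may report more compounds than this note shows. Statements on the series, on what has been measured and on what is new or still open speak of the compounds shown alone.

Measured so far in a functional assay for inhibition of sodium/hydrogen exchanger (Oryctolagus cuniculus); on this read-out higher numbers stand for weaker inhibition and lower numbers for stronger inhibition:
compound 1 `Cc1cc(-c2ccc(F)cc2)c(S(C)(=O)=O)cc1C(=O)N=C(N)N` gives 36 nM
compound 2 `Cc1cc(Sc2ccccc2Cl)c(S(C)(=O)=O)cc1C(=O)N=C(N)N` gives 14 nM

Compound 2 stands at the lower of the two numbers shown; the nearest, compound 1, sits at a 2.6-fold lower number from compound 1 to compound 2 (0.41 log units; beyond the scatter) step. Compound 3 `Cc1cc(OC(C)C)c(S(C)(=O)=O)cc1C(=O)N=C(N)N` is unmeasured; it differs from compound 2 by isopropoxy in place of (2-chlorophenyl)sulfanyl on an aromatic carbon. Going by the values given here, the only measured step, that from compound 1 to compound 2, exchanges one aromatic substituent for another at this same carbon and was modest. Among the compounds with values here, no measured step removes the aromatic ring at this position, so the change to a small alkoxy group is not covered by the data; a higher number is expected, with wide uncertainty. For compound 3 the estimate is 40 nM (range 12 nM to 130 nM), an expected 2.9-fold higher number from compound 2 to compound 3 (0.46 log units; beyond the scatter) step.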

Compound 3, half-maximal inhibitory concentration: 19 nM
Compound 3: middle estimate off by 2.1-fold (0.32 log units), on the high side; low and high end bracket the measured number.
By their numbers in this assay, from the lowest: compounds 2, 3 and 1 (each within the scatter of the next, the first and the last beyond it).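

At this carbon, ortho to a methylsulfonyl group, the substituent need not carry an aromatic ring to stay within the scatter in this assay: isopropoxy in place of (2-chlorophenyl)sulfanyl gives a 1.4-fold higher number from compound 2 to compound 3 (0.13 log units; within the scatter) and isopropoxy in place of 4-fluorophenyl gives a 1.9-fold lower number from compound 1 to compound 3 (0.28 log units; within the scatter) on the same read-out. Both aryl groups can thus be exchanged for this smaller, ring-free group without a step beyond the scatter. Nothing at hand accounts for this result. Still open, as far as these compounds go, is how an amine, a carboxylic acid or a longer alkoxy chain at this carbon would read out.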